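Piperazin-1-yl in place of methylamino on the shared core

A few compounds are considered here, and "the series" means these few. Any claim that something is new, unique, unknown or untested is made for them only; others in the source may bear on it.

In a functional assay on RKOp27 cells (Homo sapiens) for cytotoxicity, read by MTT assay, with a stated time of 3 days (a higher number here means a weaker inhibitor, a lower number a stronger inhibitor), compound 1 `N#Cc1c(Cl)nc(SCc2nc3ccccc3[nH]2)nc1-c1ccccc1` gives 4.38 nM and compound 2 `CNc1nc(SCc2nc3ccccc3[nH]2)nc(-c2ccccc2)c1C#N` gives 3.7 nM, so these two values lie within the scatter of each other. Compound 3 `N#Cc1c(-c2ccccc2)nc(SCc2nc3ccccc3[nH]2)nc1N1CCNCC1` carries piperazin-1-yl in place of methylamino on an aromatic carbon. Going by the values given here, the only measured step at this place, a 1.2-fold lower number from compound 1 to compound 2 (0.07 log units; within the scatter), stayed within the scatter, so no step beyond the scatter is expected in this assay, although no ring has been tested there. The expected step is a 1.2-fold higher number from compound 2 to compound 3 (0.09 log units; within the scatter). For compound 3 the estimated value is 4.5 nM, with an expected range of 1.5 nM to 14 nM.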

Compound 3, half-maximal inhibitory concentration: 5.81 nM
Compound 3: the middle estimate sits 1.3-fold (0.11 log units) below what was measured; the range from low to high includes it.
By their numbers in this assay, from the lowest: compounds 2, 1 and 3 (each within the scatter of the next).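

A ring at this position leaves the number in this assay within the scatter of both earlier groups: piperazin-1-yl against methylamino (a 1.6-fold higher number from compound 2 to compound 3 (0.20 log units; within the scatter)) and against chloro (a 1.3-fold higher number from compound 1 to compound 3 (0.12 log units; within the scatter)). The position thus accepts piperazin-1-yl, with 6 heavy atoms against 2 for methylamino, without a step beyond the scatter. No measured evidence explains this result. On these data alone, whether a carboxylic acid or a longer alkyl chain on this aromatic carbon would give a step beyond the scatter remains open. So does the outcome of a methyl group on the free piperazine nitrogen.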